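Rearranging one halogen pattern from compound 1

The compounds below may be only part of what the source reports. "The series", "measured", "known", "first", "only" and "open" are said of these compounds alone.

Compound 1 `C=CC(=O)Nc1cc2c(Nc3ccc(F)c(Cl)c3)ncnc2cc1OCc1cn(CCC(=O)NO)nn1`: > 25000 nM
Compound 2 `C=CC(=O)Nc1cc2c(Nc3ccc(OCc4cccc(F)c4)c(Cl)c3)ncnc2cc1OCc1cn(CCC(=O)NO)nn1`: > 25000 nM

Within the data shown here, both compounds have been tested in an ADME assay on FHC cells (Homo sapiens) for cytotoxicity, read by MTT assay, with a stated time of 72 h; a lower number here means a stronger inhibitor, a higher number a weaker inhibitor. Compound 1 gives > 25000 nM, which is a limit and not a number. Compound 2 gives > 25000 nM, which is also a limit. The data here therefore amount to the limit of > 25000 nM in this assay, at which 2 of the 2 values shown sit, so compound 1 has no exact position on the scale.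

Compound 3 `C=CC(=O)Nc1cc2c(Nc3cccc(Cl)c3F)ncnc2cc1OCc1cn(CCC(=O)NO)nn1` has not yet been measured. It has the same atoms as compound 1, joined differently: 3-chloro-2-fluorophenyl in place of 3-chloro-4-fluorophenyl on a nitrogen on an aromatic ring. In plain terms, 3-chloro-2-fluorophenyl takes the place of 3-chloro-4-fluorophenyl on a nitrogen on an aromatic ring, and the rest of the molecule stays the same.

Among the measured compounds shown here, the one measured step that bears on this is a step that the two limits leave unreadable from compound 1 to compound 2, so it offers no size to carry over. No step beyond the usual scatter is expected, in either direction. The estimated size is a number no higher from compound 1 to compound 3 (the limit leaves the size open). A report of only a limit is the most likely outcome. For compound 3 the expected value is 25000 nM, with an estimated range of 12000 nM to 50000 nM.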

Compound 3, half-maximal inhibitory concentration: > 25000 nM
Compound 3 gave a limit, no number; the forecaster's own chance of this, stated with the estimate: 80%; the middle value lies on the limit itself.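

In this assay compound 3 gives > 25000 nM as its result, which is a limit and not a number. Among these compounds, compound 1 also gives only a limit, so no step from compound 1 to compound 3 can be read. How compound 1, compound 2 and compound 3 actually compare stays open, since all that the results show is this: the limit of > 25000 nM in this assay, at which 3 of the 3 values shown sit.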